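Triazole substituent: sulfonamide-linked aryl in place of decyl

The source may hold more compounds than are shown below. What is called first, only, known or untested is meant among the compounds shown, and "the series" means these compounds.

Compound 3 `CCCCCCCCCCc1cn(C[C@H](O)[C@H]2OC(=O)C(OCc3ccccc3)=C2OCc2ccccc2)nn1` gives 12200 nM in a functional assay on HepG2 cells (Homo sapiens) for antiproliferative activity, read by MTT assay, with a stated time of 72 h (on this read-out lower numbers stand for stronger inhibition and higher numbers for weaker inhibition), the highest of the three numbers shown, though compound 2 lies within the scatter of it; compound 1 `O=C1O[C@H]([C@@H](O)Cn2cc(-c3ccc(Br)cc3)nn2)C(OCc2ccccc2)=C1OCc1ccccc1` gives 5070 nM and compound 2 `CCCCCc1ccc(-c2cn(C[C@H](O)[C@H]3OC(=O)C(OCc4ccccc4)=C3OCc3ccccc3)nn2)cc1` gives 7460 nM. The steps of a 2.4-fold higher number from compound 1 to compound 3 (0.38 log units; beyond the scatter) and a 1.6-fold higher number from compound 2 to compound 3 (0.21 log units; within the scatter) record the move from an aromatic group to decyl on an aromatic carbon. Compound 4 `O=C1O[C@H]([C@@H](O)Cn2cc(CNS(=O)(=O)c3ccc(Cl)cc3)nn2)C(OCc2ccccc2)=C1OCc1ccccc1` carries ((4-chlorophenyl)sulfonyl)amino in place of nonyl on a saturated chain carbon bound to an aromatic carbon. Among the compounds with values here, no measured step covers a sulfonyl-amino link, so only the return of a six-membered aromatic ring bears on it, read from those two steps in reverse, the larger of them modest. A modest step down in this assay is therefore expected for compound 4, a 2.0-fold lower number from compound 3 to compound 4 (0.31 log units; beyond the scatter). Compound 4 is estimated at 6000 nM, range 2500 nM to 15000 nM.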

Compound 4, half-maximal inhibitory concentration: 7510 nM
Compound 4: middle estimate off by 1.3-fold (0.10 log units), on the low side, within the range that was stated.
By their numbers in this assay, from the lowest: compounds 1, 2, 4 and 3 (each within the scatter of the next, the first and the last beyond it).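

The position accepts a sulfonyl-amino link, which brings a hydrogen-bond donor, with no step beyond the scatter in this assay: a 1.6-fold lower number from compound 3 to compound 4 (0.21 log units; within the scatter), a 1.0-fold higher number from compound 2 to compound 4 (0.00 log units; within the scatter) and a 1.5-fold higher number from compound 1 to compound 4 (0.17 log units; within the scatter). (((4-Chlorophenyl)sulfonyl)amino)methyl therefore cannot be told apart here from decyl, 4-pentylphenyl or 4-bromophenyl, each taken alone. No evidence on hand bears on this result.

Still open, going by these compounds, is whether a carboxylic acid or a primary amine at this position, or methoxy in place of the chlorine, would give a step beyond the scatter.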